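Working notes on the side-chain amine replacements

The compounds below may be only part of what the source reports. "The series", "measured", "known", "first", "only" and "open" are said of these compounds alone.

Measured so far, in a functional assay on the whole organism (strain albino) for inhibition, with Mus musculus as the target, with stated times of 30 min, 20 min and 5 min, at a dose of 25 mg/kg by the intraperitoneal route; a higher number here means more inhibition at the dose given (going by the name of the read-out), a lower number less inhibition:
compound 1, `CCN(CC)CCCOc1ccc2sc(=O)oc2c1`, gives 63.4%
compound 2, `O=c1oc2cc(OCCCN3CCNCC3)ccc2s1`, gives 68.2%

Compound 2 holds the higher of the two numbers, though the gap to compound 1 lies within the scatter. For the measured compounds named here, the one measured step is a number 4.8 percentage points higher from compound 1 to compound 2 (within the scatter), so the exchange of one saturated amine for another on the chain end has left the read-out essentially where it was.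

Compound 3, `O=c1oc2cc(OCCCn3cnnc3)ccc2s1`, is not yet measured. It differs from compound 2 as follows: 4H-1,2,4-triazol-4-yl in place of piperazin-1-yl on a saturated chain carbon, three bonds along the chain from an oxygen on an aromatic ring. Going by the values given here, the step from compound 1 to compound 2 is the only one that bears on it, and it swaps one basic saturated ring for another; the present change brings in an aromatic ring with no donor, for which no measured step exists. On the two values at hand the series has been flat, so a step of modest size in either direction, or none beyond the scatter, is expected; the estimated step is a number 8.2 percentage points lower from compound 2 to compound 3 (within the scatter). Compound 3 is therefore expected to give 60%, with a range from 38% to 80%.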

Compound 3, a percentage reported as inhibition, in the whole organism at one dose (the size of the read-out at that dose, not a potency): 79.3%
Compound 3: middle estimate off by 19.3 percentage points, on the low side; measured number inside the range.
By their numbers in this assay, from the lowest: compounds 1 and 2 (each within the scatter of the next); then compound 3.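

At the chain end, on a saturated chain carbon, three bonds along the chain from an oxygen on an aromatic ring, the read-out in this assay does respond to the group carried. With 4H-1,2,4-triazol-4-yl in place of piperazin-1-yl the result is a number 11.1 percentage points higher from compound 2 to compound 3 (beyond the scatter), and with the same group in place of diethylamino it is a number 15.9 percentage points higher from compound 1 to compound 3 (beyond the scatter). Compound 1 and compound 2 alone gave no separation at this position, whereas compound 3, with a five-membered aromatic ring and no hydrogen-bond donor, now stands clear of both as the highest of the three at this single dose. No measurement at hand accounts for the higher number.

Open, going by these compounds, is whether the gain belongs to 4H-1,2,4-triazol-4-yl in particular or to five-membered aromatic rings more widely, a question that imidazol-1-yl or 1H-1,2,4-triazol-1-yl on the same chain would address. Also open, on these data alone, is how the chain and the ring act together, which 4H-1,2,4-triazol-4-yl on a longer chain would begin to separate.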